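A few compounds are considered here, and "the series" means these few. Any claim that something is new, unique, unknown or untested is made for them only; others in the source may bear on it.

Compound 1 `COc1cc(N2C(N)=C(C#N)C(c3ccc([N+](=O)[O-])cc3)C3=C2CC(C)(C)CC3=O)cc(OC)c1OC` is the reference point of this set. In a functional assay on Ehrlich cells (Mus musculus) for cytotoxicity (a higher number here means a weaker inhibitor, a lower number a stronger inhibitor), compound 1 gives 25000 nM, the lowest of the two numbers reported. Compound 3 `COc1cc(N2C(N)=C(C#N)C(c3c(O)ccc4ccccc34)C3=C2CC(C)(C)CC3=O)cc(OC)c1OC` gives 143000 nM in this assay, and compound 2 `COc1ccc(C2C(C#N)=C(N)N(c3cc(OC)c(OC)c(OC)c3)C3=C2C(=O)CC(C)(C)C3)cc1` gives "not active" (no number reported). Within the data shown here, the one measured step, a 5.7-fold higher number from compound 1 to compound 3 (0.76 log units; beyond the scatter), exchanges the whole aryl group on the saturated ring carbon and lies beyond the scatter. Compound 4 `COc1cc(N2C(N)=C(C#N)C(c3cccc([N+](=O)[O-])c3)C3=C2CC(C)(C)CC3=O)cc(OC)c1OC` differs from compound 1 only by 3-nitrophenyl in place of 4-nitrophenyl on a saturated ring carbon. Among the measured compounds shown here, no measured pair reports a shift of the nitro group alone; the step to compound 3 changes the aryl group far more than this. Compound 4 is therefore expected to stay near compound 1, with the estimated step of a 1.6-fold higher number from compound 1 to compound 4 (0.20 log units; within the scatter), giving an expected value of 40000 nM, between 12000 nM and 150000 nM.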

Compound 4, half-maximal inhibitory concentration: "not active" (no number reported)
Compound 4 has no reported number here, and the estimate cannot be compared.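

Among these compounds, compound 4 carries no number in this assay, and no step from compound 1 to compound 4 can be read. No evidence bears on this result. The compounds shown leave open how far 3-nitrophenyl and 4-nitrophenyl differ in this assay.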